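Ethoxycarbonyl for methoxymethyl: stability on two related cores

The source may hold more compounds than are shown below. What is called first, only, known or untested is meant among the compounds shown, and "the series" means these compounds.

Measured compounds:
Compound 1 `COCC1CN(S(=O)(=O)c2ccc(F)cc2)CCN1C(C)=O`: >= 4 h
Compound 2 `COCC1CN(C(C)=O)CCN1S(=O)(=O)c1ccc(F)cc1`: >= 4 h
Compound 3 `CCOC(=O)C1CN(S(=O)(=O)c2ccc(F)cc2)CCN1C(C)=O`: >= 4 h

In a physicochemical assay for metabolic stability, read by LC-MS, in phosphate buffer, tested at 1 uM (a lower number here means that the compound disappears faster, a higher number that the compound lasts longer), compound 1 gives >= 4 h, a limit of the assay rather than a number. Compound 2 likewise gives >= 4 h, again only a limit. Compound 3 gives >= 4 h, also a limit. Compound 2 has the same atoms as compound 1 joined differently; the difference between the two cores is not broken down here. Compound 3 arises from compound 1 by ethoxycarbonyl in place of methoxymethyl on a saturated ring carbon. The step that the two limits leave unreadable from compound 1 to compound 3 cannot be read because of the limit of >= 4 h in this assay, at which 3 of the 3 values shown sit.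

Compound 4 `CCOC(=O)C1CN(C(C)=O)CCN1S(=O)(=O)c1ccc(F)cc1` is not yet measured. It arises from compound 2 by ethoxycarbonyl in place of methoxymethyl on a saturated ring carbon, the same kind of change, though in compound 2 the carbon sits next to the ring atom that bears a large group and two ring bonds from the ring atom that bears an acetyl group. Resting on the unreadable step from compound 1 to compound 3, the step that the limit leaves unreadable from compound 2 to compound 4 is expected to be small. Compound 4 is expected to give about 6 h, most likely again reported only as a limit.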

Compound 4, half-life: >= 4 h
Compound 4: no number, only a limit; the forecaster's own chance of this, stated with the estimate: 85%; the middle value is on the limit's open side.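

The step from compound 2 to compound 4 cannot be read, since both give only a limit in this assay: the limit of >= 4 h in this assay, at which 4 of the 4 values shown sit.

As far as these compounds go, how long each of the four compounds really lasts, and whether swapping methoxymethyl for ethoxycarbonyl changes that on either core, stays open.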